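A Methyl Added at a New Place on a Shared Core

This account rests on a few compounds, and the source may have more. Where it says the series, first, only, none or still open, it means among the compounds named here.

Four compounds are compared in a functional assay on J774 cells (Mus musculus) for cytotoxicity, read by resazurin assay, with a stated time of 72 h; on this read-out higher numbers stand for weaker inhibition and lower numbers for stronger inhibition. Compound 1 has the structure `O=S(=O)(Nc1cccc(CO)c1)c1ccc(-c2ccccc2)cc1` and in this assay compound 1 gives 2200 nM. Compound 2, with the structure `Cc1ccc(-c2ccc(S(=O)(=O)Nc3cccc(CO)c3)cc2)cc1`, differs from compound 1 by methyl in place of hydrogen on an aromatic carbon. In this assay compound 2 gives 1200 nM, so the step is a 1.8-fold lower number from compound 1 to compound 2 (0.26 log units; within the scatter).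

Compound 3 has the structure `Cc1c(CO)cccc1NS(=O)(=O)c1ccc(-c2ccc(F)cc2F)cc1`, and in this assay compound 3 gives 80 nM, the lowest of the three measured numbers. How the core of compound 3 differs from the core of compound 1 is not broken down here.

Compound 4, with the structure `Cc1cc(S(=O)(=O)Nc2cccc(CO)c2C)ccc1-c1ccc(F)cc1F`, has not yet been measured. It differs from compound 3 by methyl in place of hydrogen on an aromatic carbon. Within the data shown here, this is the same kind of change as the one from compound 1 to compound 2, but not the same: in compound 2 the methyl sits para to a large group, while in compound 4 it sits ortho to a 2,4-difluorophenyl group and meta to a large group. Among the measured compounds shown here, the one earlier example of this kind of change, a 1.8-fold lower number from compound 1 to compound 2 (0.26 log units; within the scatter), stayed within the scatter. On that basis the step to the unmeasured compound is expected to be small, a 1.3-fold lower number from compound 3 to compound 4 (0.12 log units; within the scatter). Compound 4 is therefore estimated to give 60 nM in this assay. For compound 4 the expected range runs from 25 nM to 150 nM.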

Compound 4, half-maximal inhibitory concentration: 25 nM
The estimate for compound 4 lay 2.4-fold (0.38 log units) above the measured number, within the range that was stated.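

In this assay, the added methyl gives a 3.2-fold lower number from compound 3 to compound 4 (0.51 log units; beyond the scatter), a modest step but one that can be read as a real change. Set beside the earlier case, the two steps do not differ by more than the scatter expected of such a comparison: the same change on two cores in this assay, a 1.8-fold lower number (0.26 log units; within the scatter) from compound 1 to compound 2 and a 3.2-fold lower number (0.51 log units; beyond the scatter) from compound 3 to compound 4, 1.7-fold (0.24 log units) apart, within the scatter of two such steps. Among these compounds, this shows that, across these two pairs, the change gave steps of comparable size, but it does not show a fixed effect that can be carried from core to core: only the step to compound 4 lies beyond the scatter, the methyl does not stand at the same place in the two pairs, and two pairs are too few to support a general rule.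

The compounds shown leave open what a methyl at the place it holds in compound 4, ortho to a 2,4-difluorophenyl group, would do on the core of compound 1. They also leave open whether a slightly larger or different group at that place, such as an ethyl group, a methoxy group or a chlorine atom, would give a step of similar size.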